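Notes on the shared core: amine nitrogen substituent, compound 4

A few compounds are considered here, and "the series" means these few. Any claim that something is new, unique, unknown or untested is made for them only; others in the source may bear on it.

In an ADME assay on microsomes from liver (Mus musculus) for metabolic stability, read by LC-MS, using NADPH, with stated times of 15 min and 60 min, tested at 4.6 uM (a lower number here means that the compound disappears faster, a higher number that the compound lasts longer), the three measured compounds stand as follows:
compound 1 `CCN1CCC(c2ccc3c(c2)oc(=O)n3C(=O)NCCCCc2ccccc2)CC1` gives 1 h
compound 2 `CC(C)N1CCC(c2ccc3c(c2)oc(=O)n3C(=O)NCCCCc2ccccc2)CC1` gives 1 h
compound 3 `CC(C)CN1CCC(c2ccc3c(c2)oc(=O)n3C(=O)NCCCCc2ccccc2)CC1` gives 1 h

Compound 3 therefore sits level with compounds 1 and 2 at the digits shown. The three steps among them are all flat: no change at the digits printed from compound 1 to compound 2 (within the scatter), no change at the digits printed from compound 1 to compound 3 (within the scatter) and no change at the digits printed from compound 2 to compound 3 (within the scatter). Each exchanges one alkyl group for another on the amine nitrogen in the ring, and none moves the half-life beyond the scatter.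

Compound 4 `CC(=O)N1CCC(c2ccc3c(c2)oc(=O)n3C(=O)NCCCCc2ccccc2)CC1` is not yet measured. It differs from compound 3 as follows: acetyl in place of isobutyl on an amine nitrogen in a ring. For the measured compounds named here, the step is at the same place as the three measured ones, but the group that enters carries a carbonyl and a hydrogen-bond acceptor, which no measured step introduces. The measured steps thus bear on it only loosely: they show that the size of the alkyl group at this nitrogen does not move the half-life, but they do not cover an acetyl group there.

With that caveat, the expected step is no change at the digits printed from compound 3 to compound 4 (within the scatter), no change beyond the scatter. Compound 4 is estimated at 1 h, with a range from 0.4 h to 3 h.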

Compound 4, half-life: 1 h
Compound 4: the middle estimate sits on the measured number at the digits printed; the range from low to high includes it.
By their numbers in this assay, from the lowest: compounds 1, 2, 3 and 4 (each within the scatter of the next).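

In this assay, an acetyl group on the amine nitrogen in the ring reads the same as the alkyl groups it replaces: no change at the digits printed from compound 3 to compound 4 (within the scatter), no change at the digits printed from compound 2 to compound 4 (within the scatter) and no change at the digits printed from compound 1 to compound 4 (within the scatter). The flat result at this position therefore extends beyond exchanges among ethyl, isopropyl and isobutyl to a group that brings a carbonyl and a hydrogen-bond acceptor, and none of the four compounds goes against it. Nothing available gives a reason for this flat result.

As far as these compounds go, it remains open whether the half-life would stay level with other groups on this nitrogen, such as a free amine hydrogen, a carboxylic acid, a benzyl group or a longer chain. All four compounds carry the same remainder of the molecule, so they cannot tell whether a change elsewhere, such as a shorter chain in place of the one ending in phenyl, would move the half-life beyond the scatter.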